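Choline kinase alpha series: removing the distal piperazine

A few compounds are considered here, and "the series" means these few. Any claim that something is new, unique, unknown or untested is made for them only; others in the source may bear on it.

Measured so far:
compound 1 `COc1ccc(-c2ccc(CN3CCCN(C)CC3)cc2)cc1` — 1430 nM
compound 2 `CN1CCCN(Cc2ccc(-c3ccc(N4CCN(C)CC4)cc3)cc2)CC1` — 1300 nM

In an assay on isolated protein for inhibition of choline kinase alpha (Homo sapiens), with a stated time of 30 min (on this read-out higher numbers stand for weaker inhibition and lower numbers for stronger inhibition), compound 1 gives 1430 nM and compound 2 gives 1300 nM. Compound 2 thus holds the lower of the two numbers, but the pair is within the scatter and no order between them can be read. For the measured compounds named here, the one step measured, a 1.1-fold lower number from compound 1 to compound 2 (0.04 log units; within the scatter), shows that exchanging methoxy for 4-methylpiperazin-1-yl on that aromatic carbon left the read-out unchanged.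

Compound 3 `CN1CCCN(Cc2ccc(-c3ccccc3)cc2)CC1` carries the change (hydrogen in place of 4-methylpiperazin-1-yl on an aromatic carbon), the group sitting on an aromatic carbon of a six-membered aromatic ring of carbon only, para to a large group. Going by the values given here, no measured step removes a group at this position entirely; the step from compound 1 to compound 2 only shows that two different substituents there behaved alike. A modest weakening is expected as the likelier outcome, a 1.9-fold higher number from compound 2 to compound 3 (0.28 log units; within the scatter), with no change beyond the scatter also plausible. Compound 3 is estimated at 2500 nM, range 1000 nM to 7000 nM.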

Compound 3, half-maximal inhibitory concentration: 1480 nM
Beside the measured number, compound 3's estimate is 1.7-fold (0.23 log units) above it, within the range that was stated.
By their numbers in this assay, from the lowest: compounds 2, 1 and 3 (each within the scatter of the next).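

In this assay, hydrogen in place of 4-methylpiperazin-1-yl on this aromatic carbon gives a 1.1-fold higher number from compound 2 to compound 3 (0.06 log units; within the scatter) and hydrogen in place of methoxy gives a 1.0-fold higher number from compound 1 to compound 3 (0.01 log units; within the scatter) in the same read-out. The earlier pair showed only that two different substituents here read alike; these steps extend that to the bare ring position, so among these three compounds neither 4-methylpiperazin-1-yl nor methoxy is needed to hold the number at this level. Nothing available bears on why this position reads so flat.

On these data alone, what a carboxylic acid or a primary amine on this aromatic carbon would give stays open. Also open, as far as these compounds go, is whether the read-out responds to any change elsewhere, since all three compounds share the rest of the core of compound 1 unchanged.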